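A few compounds are considered here, and "the series" means these few. Any claim that something is new, unique, unknown or untested is made for them only; others in the source may bear on it.

Compounds measured so far in an ADME assay on A549 cells (Homo sapiens) for cytotoxicity, read by resazurin assay, with a stated time of 48 h; on this read-out lower numbers stand for higher toxicity in this test and higher numbers for lower toxicity in this test:
- compound 1 `CCCCCCC(C)Nc1ccc(NC(=O)c2cc(Cl)ccc2O)c(Cl)c1`: 23500 nM
- compound 2 `O=C(Nc1ccc(NCc2ccccc2)cc1Cl)c1cc(Cl)ccc1O`: 19700 nM
- compound 3 `O=C(Nc1ccc(NCc2cc(Cl)cc(C(F)(F)F)c2)cc1Cl)c1cc(Cl)ccc1O`: 30900 nM

Compound 2 carries the lowest number of the three, but its gaps to compound 1 and to compound 3 both lie within the scatter, so the three cannot be ordered by toxicity on these numbers. Among the measured compounds shown here, the only single-place step is a 1.2-fold lower number from compound 1 to compound 2 (0.08 log units; within the scatter), which likewise falls within the scatter. Compound 3 differs from compound 2 in substituents on the benzyl ring and sits within the scatter of it.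

Compound 4 `O=C(Nc1ccc(NCc2ccc(O)nc2)cc1Cl)c1cc(Cl)ccc1O` is built from compound 2 by 6-hydroxypyridin-3-yl in place of phenyl on a saturated chain carbon bound to a nitrogen on an aromatic ring. For the measured compounds named here, no measured pair swaps the benzyl ring itself for a different ring, so nothing bears directly on this change; the nearest information is that varying the group on the ring nitrogen, from 1-methylheptyl to benzyl to the substituted benzyl of compound 3, moved this read-out by less than the scatter in every case. The expectation for compound 4 is therefore a step of no more than the scatter, a 1.1-fold higher number from compound 2 to compound 4 (0.05 log units; within the scatter), in no set direction. Compound 4 is estimated at 22000 nM, with a likely range from 9000 nM to 55000 nM.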

Compound 4, half-maximal cytotoxic concentration: 98500 nM
Beside the measured number, compound 4's estimate is 4.5-fold (0.65 log units) below it; the measured number lies above the stated range.
By their numbers in this assay, from the lowest: compounds 2, 1 and 3 (each within the scatter of the next); then compound 4.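

In this assay, the group on the saturated chain carbon bound to a nitrogen on an aromatic ring can move the read-out beyond the scatter: 6-hydroxypyridin-3-yl in place of phenyl gives a 5.0-fold higher number from compound 2 to compound 4 (0.70 log units; beyond the scatter) in the direction of lower toxicity in this test. The earlier change at this nitrogen stayed within the scatter, whereas (6-hydroxypyridin-3-yl)methyl in place of 1-methylheptyl gives a 4.2-fold higher number from compound 1 to compound 4 (0.62 log units; beyond the scatter) in the same direction, so the shift appears against both an aryl-bearing and a purely alkyl neighbour. The data shown offer no measured explanation for this shift.

Still open, on these data alone, is whether the ring nitrogen or the hydroxyl accounts for the step, a question that a pyridinyl without the hydroxyl and a hydroxyphenyl at the same place would separate. Also open, as far as these compounds go, is whether other groups on this ring, such as a carboxylic acid or an amine, would give a step of similar size.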